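The source may hold more compounds than are shown below. What is called first, only, known or untested is meant among the compounds shown, and "the series" means these compounds.

In a functional assay on Bel7402/5-FU cells (Homo sapiens) for antiproliferative activity, read by MTT assay, with a stated time of 72 h (on this read-out lower numbers stand for stronger inhibition and higher numbers for weaker inhibition), compound 1 `C=C1C(=O)O[C@H]2[C@H]1CC/C(Cn1cc(Cn3cc(F)c(=O)[nH]c3=O)nn1)=C\CC[C@@]1(C)O[C@@H]21` gives > 20000 nM, which is a limit of the assay and not a number. Among the compounds with values here, compound 2 `C=C1C(=O)O[C@H]2[C@H]1CC/C(COC(=O)Cn1cc(F)c(=O)n(Cc3ccccc3)c1=O)=C\CC[C@@]1(C)O[C@@H]21` gives 4270 nM, the only true number so far. Compound 3 `C=C1C(=O)O[C@H]2[C@H]1CC/C(COC(=O)Cn1cc(F)c(=O)n(Cc3ccc(Cl)cc3)c1=O)=C\CC[C@@]1(C)O[C@@H]21` differs from compound 2 by chloro in place of hydrogen on an aromatic carbon, turning benzyl into 4-chlorobenzyl: chloro in place of hydrogen on an aromatic carbon. Within the data shown here, no measured pair shows this change. In this assay, a small estimated move towards stronger inhibition is expected, the step of a 1.4-fold lower number from compound 2 to compound 3 (0.15 log units; within the scatter), and it may not exceed the usual scatter. The estimate for compound 3 is 3000 nM, with an expected range of 1200 nM to 8000 nM.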

Compound 3, half-maximal inhibitory concentration: 2420 nM
For compound 3 the middle estimate is 1.2-fold (0.09 log units) above the measured one; the measured number falls inside the stated range.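

In this assay chloro in place of hydrogen on the aromatic carbon para to a large group gives a 1.8-fold lower number from compound 2 to compound 3 (0.25 log units; within the scatter) and so shows that this position accepts the chloro atom while the number stays within the usual scatter. On this evidence, benzyl and 4-chlorobenzyl cannot be told apart. Nothing at hand gives a cause for this step. Still open, as far as these compounds go, is whether a methoxy group, a nitrile or an amine at this carbon would move the number beyond the scatter. Also open, from the compounds shown here alone, is what a chloro on another carbon of this ring would do.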